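This account rests on a few compounds, and the source may have more. Where it says the series, first, only, none or still open, it means among the compounds named here.

Working notes on the series in a functional assay on MDA-MB-231 cells (Homo sapiens) for cytotoxicity; on this read-out higher numbers stand for weaker inhibition and lower numbers for stronger inhibition. Compound 1 `COc1ccc(Cn2cc(/C=N\NC(=O)c3c[nH]c4ccc(Br)cc34)c3cc(OC)ccc32)cc1` gives 61200 nM. Compound 2 `COc1ccc2c(c1)c(/C=N\NC(=O)c1c[nH]c3ccc(Br)cc13)cn2Cc1ccc(Cl)cc1` gives 5000 nM; the step of a 12-fold lower number from compound 1 to compound 2 (1.09 log units; beyond the scatter) goes with the change (chloro in place of methoxy on an aromatic carbon). Compound 3 `COc1ccc(Cn2cc(/C=N\NC(=O)c3c[nH]c4ccc(Br)cc34)c3ccc(F)cc32)cc1` gives 99800 nM, which stands within the scatter of compound 1 and beyond the scatter of compound 2; the difference between the cores of compound 3 and compound 1 is not broken down here. Compound 4 `O=C(N/N=C\c1cn(Cc2ccc(Cl)cc2)c2cc(F)ccc12)c1c[nH]c2ccc(Br)cc12` has not yet been measured in this assay. It differs from compound 3 by chloro in place of methoxy on an aromatic carbon, the same change as from compound 1 to compound 2, at a place described in the same words. On the strength of a 12-fold lower number from compound 1 to compound 2 (1.09 log units; beyond the scatter) a step of comparable size is expected for the new pair, with the caution that this rests on a single earlier pair on a different core, so the range is kept wide. The expected step is a 10-fold lower number from compound 3 to compound 4 (1.00 log units; beyond the scatter). Compound 4 is estimated at 10000 nM, with the expected range running from 3000 nM to 40000 nM.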

Compound 4, half-maximal inhibitory concentration: 5100 nM
Compound 4: middle estimate off by 2.0-fold (0.29 log units), on the high side, and the stated range covers the measured number.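

In this assay the change from 4-methoxybenzyl to 4-chlorobenzyl goes with a 20-fold lower number from compound 3 to compound 4 (1.29 log units; beyond the scatter) as a large step, in the same direction as on the core of compound 1. Among these compounds, two pairs show only that the change carries across these two cores; they do not show that it would hold on any further core, and they give no reason why chloro goes with the lower numbers. On these two cores the size of the step carries over as well, with no difference between the two pairs beyond what repeated measurements would give: the same change on two cores in this assay, a 12-fold lower number (1.09 log units; beyond the scatter) from compound 1 to compound 2 and a 20-fold lower number (1.29 log units; beyond the scatter) from compound 3 to compound 4, 1.6-fold (0.20 log units) apart, within the scatter of two such steps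

The compounds shown carry only methoxy or chloro at this place, on a six-membered aromatic ring of carbon only and para to a large group, so it stays open whether a nitrile, an amine or a carboxylic acid there would go with numbers like those of chloro or those of methoxy. Also open, on these data alone, is whether the same step would appear if the bromo group, common to all four compounds, gave way to a hydrogen or a methyl.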